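Chlorinated fused-core benzyl series: growth inhibition notes

The compounds below may be only part of what the source reports. "The series", "measured", "known", "first", "only" and "open" are said of these compounds alone.

Measured so far in a functional assay on RXF 393 cells (Homo sapiens) for cytotoxicity, read by sulforhodamine B assay, with a stated time of 48 h; a higher number here means a weaker inhibitor of growth, a lower number a stronger inhibitor of growth:
compound 1 `ClCc1ccc(Cn2cnc3c(Cl)ncnc32)cc1` gives 5490 nM;
compound 2 `ClCc1cccc(Cn2cnc3ncnc(Cl)c32)c1` gives 17400 nM;
compound 3 `ClCc1ccc(Cn2cnc3c(Cl)nc(Cl)nc32)cc1` gives 41700 nM.

Compound 1 and compound 2 carry the same atoms joined differently; the difference between the two cores is not broken down here. Compound 3 is made from compound 1 by one change: chloro in place of hydrogen on an aromatic carbon This step is a 7.6-fold higher number from compound 1 to compound 3 (0.88 log units; beyond the scatter).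

Compound 4 `ClCc1cccc(Cn2cnc3nc(Cl)nc(Cl)c32)c1` is not yet measured. It arises from compound 2 by the same change, at a place described in the same words: chloro in place of hydrogen on an aromatic carbon

For the measured compounds named here, the expectation for compound 4 rests on the single measured step from compound 1 to compound 3, so the step from compound 2 to compound 4 is estimated as a 6.3-fold higher number from compound 2 to compound 4 (0.80 log units; beyond the scatter), with the weaker growth inhibition carried over. On that basis compound 4 is expected to give about 110000 nM in this assay, estimated between 40000 nM and 300000 nM.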

Compound 4, concentration for total growth inhibition: 2630 nM
Compound 4: the middle estimate sits 42-fold (1.62 log units) above what was measured, and the stated range ends above it.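

In this assay chloro in place of hydrogen on an aromatic carbon did not carry over from one core to the other, with a 6.6-fold lower number from compound 2 to compound 4 (0.82 log units; beyond the scatter) running against the earlier step: the same change on two cores in this assay, a 7.6-fold higher number (0.88 log units; beyond the scatter) from compound 1 to compound 3 and a 6.6-fold lower number (0.82 log units; beyond the scatter) from compound 2 to compound 4, 50-fold (1.70 log units) apart, beyond the scatter of two such steps. In these two pairs, the result of the change therefore depends on the core, and a step read on one core gives no safe estimate for the other. What lies behind the opposite directions is not shown, as the two pairs differ from each other in more than one place and rest on single steps.

From the compounds shown here alone, whether an amine or a methoxy group at this place would follow either step remains open. Also open, going by these compounds, is whether the opposite directions hold on cells other than those tested here.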